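A few compounds are considered here, and "the series" means these few. Any claim that something is new, unique, unknown or untested is made for them only; others in the source may bear on it.

Measured so far:
compound 1 `CCCCCCCCCNC(=O)[C@H]1OC(n2cnc3c(N)ncnc32)[C@H](O)[C@@H]1O` gives 31 nM
compound 2 `CCCCCCCCCCCNC(=O)[C@H]1OC(n2cnc3c(N)ncnc32)[C@H](O)[C@@H]1O` gives 123 nM
compound 3 `CC(=O)NCCCCCCCCNC(=O)[C@H]1OC(n2cnc3c(N)ncnc32)[C@H](O)[C@@H]1O` gives 10 nM

All three were tested in an assay on cell membranes for binding affinity to 2-oxoglutarate receptor 1 (Rattus norvegicus), read by radioligand binding; on this read-out lower numbers stand for stronger inhibition and higher numbers for weaker inhibition. Compound 1 stands second highest of the three numbers; the step of a 4.0-fold higher number from compound 1 to compound 2 (0.60 log units; beyond the scatter) was modest, and the step of a 3.1-fold lower number from compound 1 to compound 3 (0.49 log units; beyond the scatter) was modest in the other direction.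

Compound 4 `CC1CCCCC1NC(=O)[C@H]1OC(n2cnc3c(N)ncnc32)[C@H](O)[C@@H]1O` is not yet measured. It differs from compound 1 by 2-methylcyclohexyl in place of nonyl on an amide-type nitrogen. Among the compounds with values here, no measured step swaps the chain for a ring: the steps from compound 1 only lengthen the chain or cap it with acetamido, so they bear on compound 4 only loosely. A modest step in either direction is therefore plausible, and compound 4 is expected near compound 1, estimated at 60 nM (range 15 nM to 250 nM), a step of a 1.9-fold higher number from compound 1 to compound 4 (0.29 log units; within the scatter).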

Compound 4, inhibition constant: 69.5 nM
The estimate for compound 4 lay 1.2-fold (0.06 log units) below the measured number; low and high end bracket the measured number.
By their numbers in this assay, from the lowest: compound 3; then compound 1; then compounds 4 and 2 (each within the scatter of the next).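

The step of a 2.2-fold higher number from compound 1 to compound 4 (0.35 log units; beyond the scatter) shows that the amide-type nitrogen can carry a ring as well as a straight chain: 2-methylcyclohexyl in place of nonyl weakens binding only modestly. The earlier compounds shown here changed only the length of the chain or the cap at its end, so they could not show this. Nothing measured here gives a reason for this step. Still open, going by these compounds, is what the methyl on the ring contributes, and how plain cyclohexyl or a phenyl ring would compare on this nitrogen.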